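Chloro to bromo exchange in two related pairs

The compounds below may be only part of what the source reports. "The series", "measured", "known", "first", "only" and "open" are said of these compounds alone.

Measured compounds:
compound 1 `Cc1ccc(S(=O)(=O)NC(=O)/C=C/c2ccc(Cl)cc2)cc1` — 4.6 ug/mL
compound 2 `Cc1ccc(S(=O)(=O)NC(=O)/C=C/c2ccc(Br)cc2)cc1` — 12.1 ug/mL
compound 3 `CN(C)c1ccc(/C=C/C(=O)NS(=O)(=O)c2ccc(Cl)cc2)cc1` — 2.8 ug/mL

All three were run in a functional assay on B16-F10 cells (Mus musculus) for antiproliferative activity, read by ELISA and MTT assay, with a stated time of 48 h; on this read-out lower numbers stand for stronger inhibition and higher numbers for weaker inhibition. Compound 4 `CN(C)c1ccc(/C=C/C(=O)NS(=O)(=O)c2ccc(Br)cc2)cc1` has not yet been measured in this assay.

Compound 1 and compound 2 differ in one place only: bromo in place of chloro on an aromatic carbon. In this assay that change produced a 2.6-fold higher number from compound 1 to compound 2 (0.42 log units; beyond the scatter). Compound 3 differs from compound 1 in more than one place; the difference between the two cores is not broken down here. Compound 4 is related to compound 3 by the same single change: bromo in place of chloro on an aromatic carbon. The surroundings of the place are the same in both pairs, so this is the same change, made twice among the compounds shown.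

Compound 3 and compound 1 lie within the scatter of each other in this assay, so no order between them is claimed. Compound 2 sits beyond the scatter from compound 3.

Within the data shown here, for compound 4 only one precedent exists. The step from compound 3 to compound 4 is expected to be a 2.3-fold higher number from compound 3 to compound 4 (0.37 log units; beyond the scatter), because the same change in this assay gave a 2.6-fold higher number from compound 1 to compound 2 (0.42 log units; beyond the scatter); with one precedent on a different core, a somewhat smaller step is taken as the middle. In this assay compound 4 is thus estimated at 6.5 ug/mL, expected between 3 ug/mL and 14 ug/mL.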

Compound 4, half-maximal inhibitory concentration: 4.2 ug/mL
Compound 4: the middle estimate sits 1.5-fold (0.19 log units) above what was measured, within the range that was stated.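

In this assay, bromo in place of chloro on the second core gives a 1.5-fold higher number from compound 3 to compound 4 (0.18 log units; within the scatter), so on that core the exchange cannot be told apart from repeat measurement. Set beside the earlier step, the two results do not separate by core: the same change on two cores in this assay, a 2.6-fold higher number (0.42 log units; beyond the scatter) from compound 1 to compound 2 and a 1.5-fold higher number (0.18 log units; within the scatter) from compound 3 to compound 4, 1.8-fold (0.24 log units) apart, within the scatter of two such steps. This means that one step lying beyond the scatter and the other within it is no evidence that the core alters the effect of the change, but two pairs also do not establish that the change carries over at a fixed size to other cores in the series.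

The compounds shown leave open whether fluoro, iodo or a nitrile in the same place would fit with the chloro and bromo results, and whether the step would hold on a core carrying an amine, a carboxylic acid or a longer chain. Among these compounds, they also leave open which of the several differences between the core of compound 1 and the core of compound 3 bears on the values, as no pair here isolates any one of those differences.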